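This account rests on a few compounds, and the source may have more. Where it says the series, first, only, none or still open, it means among the compounds named here.

Compound 1 `CC(=O)Nc1ccc(S(=O)(=O)Oc2ccccc2C(C)C)cc1` is the plain acetamide of the series; in a functional assay on M21 cells (Homo sapiens) for antiproliferative activity, read by sulforhodamine B assay, with a stated time of 48 h (a lower number here means a stronger inhibitor, a higher number a weaker inhibitor), compound 1 gives 21000 nM. Compound 2 `CC(C)c1ccccc1OS(=O)(=O)c1ccc(NC(=O)CCl)cc1` carries a chloro in place of hydrogen on the saturated chain carbon bound to the carbonyl carbon, and in this assay compound 2 gives 3900 nM. Among the measured compounds shown here, that single change brought a 5.4-fold lower number from compound 1 to compound 2 (0.73 log units; beyond the scatter), so compound 2 holds the lowest of the two numbers recorded so far, with compound 1 as its only neighbour.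

Compound 3 `CC(C)c1ccccc1OS(=O)(=O)c1ccc(NC(=O)CCCl)cc1` differs from compound 2 by chloromethyl in place of chloro on a saturated chain carbon bound to a carbonyl carbon. For the measured compounds named here, no measured step extends the chain in this way; the only step available, from compound 1 to compound 2, concerns the arrival of the chloro itself rather than its distance from the carbonyl. The chloro is kept in compound 3, so the large part of the gain seen in a 5.4-fold lower number from compound 1 to compound 2 (0.73 log units; beyond the scatter) is expected to be retained, but with a modest move back toward compound 1, since the change adds a carbon the earlier step never tested. Compound 3 is therefore expected to give 8000 nM in this assay, within 2500 nM to 25000 nM, a step of a 2.1-fold higher number from compound 2 to compound 3 (0.31 log units; beyond the scatter).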

Compound 3, half-maximal inhibitory concentration: 14000 nM
Estimate against measurement, compound 3: 1.8-fold (0.24 log units) below; the range from low to high includes it.
By their numbers in this assay, from the lowest: compound 2; then compounds 3 and 1 (each within the scatter of the next).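

In this assay the saturated chain carbon bound to a carbonyl carbon proves sensitive to more than whether the side chain holds a chlorine at all: chloromethyl in place of chloro brings a 3.6-fold higher number from compound 2 to compound 3 (0.56 log units; beyond the scatter) and so gives back much of what the chloro had gained. Against the plain acetamide, the same chlorine-bearing chain gives a 1.5-fold lower number from compound 1 to compound 3 (0.18 log units; within the scatter) and thus compound 3 cannot be told apart from compound 1, which leaves compound 2, with chloro directly on that carbon, as the only one of the three that stands clear of the others. Nothing given here explains why the chloromethyl group behaves so differently from the chloro.

The three compounds leave open whether this sensitivity is specific to chlorine, since a bromo or a fluoro on that same carbon would be needed to tell, and whether a longer chain ending in chloro would stay level with compound 3. Among the compounds shown here, they also leave open how an amine or a hydroxyl at this place would compare, and whether the step seen here holds on any core other than the one these compounds share.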